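A few compounds are considered here, and "the series" means these few. Any claim that something is new, unique, unknown or untested is made for them only; others in the source may bear on it.

Working notes on the series. The core of compound 1 `CCCCCCCCC#Cc1cn(C/C=C/CN2C(=O)c3ccccc3C2=O)c(=O)[nH]c1=O` carries a triple bond that ends in a saturated chain. In a functional assay on MOLT-4 cells (Homo sapiens) for antiproliferative activity, read by MTT assay, with a stated time of 3 days (on this read-out higher numbers stand for weaker inhibition and lower numbers for stronger inhibition), compound 1 gives > 250000 nM; this is a limit of the assay and not a number. Compound 2 `CCCCCC#Cc1cn(C/C=C/CN2C(=O)c3ccccc3C2=O)c(=O)[nH]c1=O` keeps the same core with a shorter chain, hydrogen in place of propyl on a saturated chain carbon, five bonds along the chain from a triple-bonded carbon. In this assay compound 2 gives > 500000 nM, which is again a limit rather than a number. Among the compounds with values here, the step that the two limits leave unreadable from compound 1 to compound 2 cannot be sized, since the limit of > 250000 nM in this assay, at which 1 of the 2 values shown sits, and the limit of > 500000 nM in this assay, at which 1 of the 2 values shown sits, show only that neither compound reached a measurable value in this assay. On the numbers shown, compound 2 therefore stands at a limit, with no measured potency, and every value in the set so far is a limit.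

Compound 3 `CCCCCc1ccc(C#Cc2cn(C/C=C/CN3C(=O)c4ccccc4C3=O)c(=O)[nH]c2=O)cc1` differs from compound 2 by 4-pentylphenyl in place of pentyl on a triple-bonded carbon. Within the data shown here, no measured step bears on an aromatic ring on the triple-bonded carbon; the only step available is unreadable. A step of an at least 2.5-fold lower number from compound 2 to compound 3 (0.39 log units; beyond the scatter) is expected, with a limit again the likeliest outcome. Compound 3 is estimated at 200000 nM, with a range from 30000 nM to 1000000 nM.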

Compound 3, half-maximal inhibitory concentration: 17000 nM
For compound 3 the middle estimate is 12-fold (1.07 log units) above the measured one; the whole stated range lies above it.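

On the triple-bonded carbon, 4-pentylphenyl gives the first measured value of the series in this assay, with compound 3 at 17000 nM, whereas the two saturated chains shown here give no number. Putting 4-pentylphenyl in place of pentyl gives an at least 29-fold lower number from compound 2 to compound 3 (1.46 log units; beyond the scatter), and putting it in place of octyl gives an at least 14-fold lower number from compound 1 to compound 3 (1.16 log units; beyond the scatter), so the group on this carbon can move the read-out, which the unreadable step between the two saturated chains could not show. Each step starts from a limit and not from a number, so it gives only a floor on the size of the change; for compound 2 the starting point is: the limit of > 500000 nM in this assay, at which 1 of the 3 values shown sits.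

The compounds shown leave open whether the step belongs to the aromatic ring itself or to the pentyl it carries, a question on which a plain phenyl on the triple-bonded carbon would bear. Also open, from the compounds shown here alone, is how the read-out responds when 4-pentylphenyl gives way to 4-hexylphenyl, with its longer chain, or to an aminophenyl group.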